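Swapping Pyridine for Trifluoromethylphenyl on a Weaker Core

The source may hold more compounds than are shown below. What is called first, only, known or untested is meant among the compounds shown, and "the series" means these compounds.

Compound 1 `C=C1C(=O)[C@]23C[C@@]1(O)CC[C@H]2c1ccc(O)c(C)c1[C@@H]3Cn1cc(-c2ccccn2)nn1` and compound 2 `C=C1C(=O)[C@]23C[C@@]1(O)CC[C@H]2c1ccc(O)c(C)c1[C@@H]3Cn1cc(-c2ccc(C(F)(F)F)cc2)nn1` share one core and differ in a single group on the triazole ring: 4-(trifluoromethyl)phenyl in place of pyridin-2-yl on an aromatic carbon. In a functional assay on HL-60 cells (Homo sapiens) for cytotoxicity, read by MTT assay, with a stated time of 4 days (a higher number here means a weaker inhibitor, a lower number a stronger inhibitor), compound 1 gives 1970 nM, and compound 2 gives 720 nM. That change made a 2.7-fold lower number from compound 1 to compound 2 (0.44 log units; beyond the scatter). Compound 3 `C=C1C[C@]23C[C@@]1(O)CC[C@H]2c1cc(Br)c(O)c(C)c1[C@@H]3Cn1cc(-c2ccccn2)nn1` rests on a different core; how its core differs from the core of compound 1 is not broken down here. In this assay compound 3 reaches only > 20000 nM, which is a limit of the measurement and not a number. Compound 4 `C=C1C[C@]23C[C@@]1(O)CC[C@H]2c1cc(Br)c(O)c(C)c1[C@@H]3Cn1cc(-c2ccc(C(F)(F)F)cc2)nn1` carries the same change on the core of compound 3: 4-(trifluoromethyl)phenyl in place of pyridin-2-yl on an aromatic carbon. A similar size of step is expected here, an at least 1.3-fold lower number from compound 3 to compound 4 (0.12 log units; that floor lies within the scatter), resting on a 2.7-fold lower number from compound 1 to compound 2 (0.44 log units; beyond the scatter). Because compound 3 sits at the limit of > 20000 nM in this assay, at which 1 of the 3 values shown sits, compound 4 is expected to remain weak, around 15000 nM, with a fair chance that this assay again reports only a limit.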

Compound 4, half-maximal inhibitory concentration: 7380 nM
For compound 4 the middle estimate is 2.0-fold (0.31 log units) above the measured one; the range from low to high includes it.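

In this assay, 4-(trifluoromethyl)phenyl in place of pyridin-2-yl on the second core goes with an at least 2.7-fold lower number from compound 3 to compound 4 (0.43 log units; beyond the scatter). Going by these compounds, compound 3 gives only > 20000 nM, which is a limit of the assay and not a number, so the true size of that step stays open. The change points the same way on both cores, but these data cannot show whether its size carries over exactly: the same change on two cores in this assay, a 2.7-fold lower number (0.44 log units; beyond the scatter) from compound 1 to compound 2 and an at least 2.7-fold lower number (0.43 log units; beyond the scatter) from compound 3 to compound 4; the limit leaves it open whether they differ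

Two cores are too few to say whether the same direction would hold on a third. The compounds shown also leave open how an amine or a carboxylic acid at the same place would compare with these two aromatic groups in this assay.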